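Two Limits Before an Untested Ring-Bearing Side Chain

The compounds below may be only part of what the source reports. "The series", "measured", "known", "first", "only" and "open" are said of these compounds alone.

Compound 1 `O=c1cc(Cn2cc(CCO)nn2)c2ccc(O)cc2o1`: > 100000 nM (a limit)
Compound 2 `CCCCCCc1cn(Cc2cc(=O)oc3cc(O)ccc23)nn1`: > 100000 nM (a limit)

In a functional assay on SW-620 cells (Homo sapiens) for inhibition, read by MTT assay, with a stated time of 72 h (a lower number here means a stronger inhibitor, a higher number a weaker inhibitor), compound 1 gives > 100000 nM, which is a limit of the assay rather than a number. Compound 2 in turn gives > 100000 nM, also a limit. The step that the two limits leave unreadable from compound 1 to compound 2 therefore cannot be sized, and the limit of > 100000 nM in this assay, at which 2 of the 2 values shown sit, is all the two values reveal. Compound 2 thus stands only at a limit, with no readable number of its own.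

Compound 3 `O=c1cc(Cn2cc(CSC(=S)N3CCOCC3)nn2)c2ccc(O)cc2o1` differs from compound 2 by a group of 9 heavy atoms (5 carbon, 1 nitrogen, 1 oxygen, 2 sulfur; one six-membered non-aromatic ring with 2 hetero atoms) in place of a group of 5 heavy atoms (5 carbon; no ring), on a saturated chain carbon bound to an aromatic carbon. Among the compounds with values here, the one measured step, a step that the two limits leave unreadable from compound 1 to compound 2, bears on a different position and was unreadable, so no step beyond the scatter can be argued from the data in either direction. Compound 3 is accordingly estimated at 80000 nM, within 15000 nM to 200000 nM, with a good chance that only a limit is reported again. The expected step is an at least 1.2-fold lower number from compound 2 to compound 3 (0.09 log units; that floor lies within the scatter).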

Compound 3, half-maximal inhibitory concentration: >= 100000 nM
Compound 3: only a limit was reported; the forecaster's own chance of this, stated with the estimate: 55%; at least 1.2-fold (0.09 log units) between middle value and limit.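

In this assay compound 3 gives >= 100000 nM, a limit and not a number. None of the steps linking compound 1, compound 2 and compound 3 can be read. The compounds shown leave open whether any side chain on the shared core gives a readable value in this assay.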